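A few compounds are considered here, and "the series" means these few. Any claim that something is new, unique, unknown or untested is made for them only; others in the source may bear on it.

Compound 1 `COc1cc(C2=NN(C(C)=O)C(c3cccc(F)c3)O2)cc(OC)c1OC` gives 37.7% in a functional assay on BGC-823 cells (Homo sapiens) for antiproliferative activity, read by MTT assay, tested at 5 uM (on this read-out higher numbers stand for a stronger effect at the one concentration tested and lower numbers for a weaker effect), the highest of the three numbers available, although the value of compound 2 `COc1cc(C(=O)N/N=C/c2ccccc2C(F)(F)F)cc(OC)c1OC`, which gives 35.6% in this assay, lies within the scatter and so cannot be ranked against it. Compound 3 `COc1cc(C2=NN(C(C)=O)C(c3cc(OC)c(OC)c(OC)c3)O2)cc(OC)c1OC` gives -1.4% in this assay, a gap beyond the scatter. Compound 4 `COc1cc(C2=NN(C(C)=O)C(c3ccc(Cl)c(Cl)c3)O2)cc(OC)c1OC` carries one change from compound 1: 3,4-dichlorophenyl in place of 3-fluorophenyl on a saturated ring carbon. For the measured compounds named here, no measured pair shows a halogen swap of this kind, so the size of the step is uncertain. Compound 4 is expected to land close to compound 1, with a step of a number 4.3 percentage points higher from compound 1 to compound 4 (within the scatter), likely within the scatter. The estimate for compound 4 in this assay is 42%, in a range from 22% to 62%.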

Compound 4, a percentage reported as inhibition, at one concentration (the size of the read-out at that concentration, not a potency): 3.1%
The estimate for compound 4 lay 38.9 percentage points above the measured number; the whole stated range lies above it.
By their numbers in this assay, from the lowest: compounds 3 and 4 (each within the scatter of the next); then compounds 2 and 1 (each within the scatter of the next).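

Swapping the group on this saturated ring carbon is far from a neutral exchange: in this assay, 3,4-dichlorophenyl in place of 3-fluorophenyl gives a number 34.6 percentage points lower from compound 1 to compound 4 (beyond the scatter). This is the first pair shown that differs in one place, so it shows directly that the result at this position depends strongly on which substituted phenyl ring sits there. Nothing measured here accounts for the drop. Still open, as far as these compounds go, is how a phenyl ring carrying a single chlorine, a plain phenyl ring or a phenyl ring bearing an amine would behave at this position. Whether the drop follows from the number of halogens or from their kind also remains unsettled.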